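3,4-Dimethoxyphenyl to 2-fluorophenyl on a shared core

The source may report more compounds than this note shows. Statements on the series, on what has been measured and on what is new or still open speak of the compounds shown alone.

Compound 1 `C[C@H]1CC[C@@H]2[C@@H](OC(=O)[C@]23CC(c2ccccc2)=NO3)[C@]2(C)C(=O)C=C[C@@]12O`: 45400 nM
Compound 2 `C[C@H]1CC[C@@H]2[C@@H](OC(=O)[C@]23CC(c2ccc(O)cc2)=NO3)[C@]2(C)C(=O)C=C[C@@]12O`: 89000 nM
Compound 3 `COc1ccc(C2=NO[C@]3(C2)C(=O)O[C@@H]2[C@H]3CC[C@H](C)[C@]3(O)C=CC(=O)[C@@]23C)cc1OC`: 86000 nM

These three values come from a functional assay on SW-620 cells (Homo sapiens) for cytotoxicity, read by sulforhodamine B assay, with a stated time of 48 h; a lower number here means a stronger inhibitor, a higher number a weaker inhibitor. Compound 3, at 86000 nM, cannot be told apart from the other two. Its link to one is a 1.0-fold lower number from compound 2 to compound 3 (0.01 log units; within the scatter), and its link to the other is a 1.9-fold higher number from compound 1 to compound 3 (0.28 log units; within the scatter).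

The next molecule is compound 4 `C[C@H]1CC[C@@H]2[C@@H](OC(=O)[C@]23CC(c2ccccc2F)=NO3)[C@]2(C)C(=O)C=C[C@@]12O`, which has 2-fluorophenyl in place of 3,4-dimethoxyphenyl on a carbon with a double bond to nitrogen.

Among the compounds with values here, two measured steps bear most directly on this change. Exchanging the aromatic group at this same carbon gave a 1.9-fold higher number from compound 1 to compound 3 (0.28 log units; within the scatter), and adding hydroxy to the aromatic ring gave a 2.0-fold higher number from compound 1 to compound 2 (0.29 log units; within the scatter). Both stay within the scatter, so the three measured aromatic groups show no real separation in this assay. Within the data shown here, none of the measured compounds carries fluorine, however, so that part of the change is untested. A step beyond the scatter is therefore not expected, and no firm direction can be claimed.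

The expected step is a 1.4-fold lower number from compound 3 to compound 4 (0.14 log units; within the scatter). For compound 4, the estimated value is 62000 nM, with an expected range from 27000 nM to 140000 nM.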

Compound 4, half-maximal inhibitory concentration: 11000 nM
Beside the measured number, compound 4's estimate is 5.6-fold (0.75 log units) above it; the measured number lies below the stated range.
By their numbers in this assay, from the lowest: compound 4; then compounds 1, 3 and 2 (each within the scatter of the next).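

In this assay this position had looked indifferent, since the phenyl, 4-hydroxyphenyl and 3,4-dimethoxyphenyl compounds all stayed within the scatter of one another. Compound 4 changes that picture: fluoro in place of hydrogen on an aromatic carbon gives a 4.1-fold lower number from compound 1 to compound 4 (0.62 log units; beyond the scatter) and so produces a real difference at this carbon, the one with a double bond to nitrogen, from a change of a single atom on the ring. The exchanges of the larger substituted rings point the same way, with a 7.8-fold lower number from compound 3 to compound 4 (0.89 log units; beyond the scatter) for 2-fluorophenyl in place of 3,4-dimethoxyphenyl and an 8.1-fold lower number from compound 2 to compound 4 (0.91 log units; beyond the scatter) for 2-fluorophenyl in place of 4-hydroxyphenyl, which makes compound 4 the strongest inhibitor of the four. No measurement offered here explains why the 2-fluorophenyl group stands apart from the other aromatic groups.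

Going by these compounds, with a single fluorinated compound, it remains open whether this step belongs to fluorine in particular or would also follow from another small group on the phenyl ring, such as chloro or methyl. On these data alone, it is equally open whether the ring itself is needed, which a pyridine ring or a simple alkyl chain at this carbon could test.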